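Swapping Azido for Amino at One Aromatic Carbon

This account rests on a few compounds, and the source may have more. Where it says the series, first, only, none or still open, it means among the compounds named here.

Compound 1 `O=c1[nH]c(=O)n([C@@H]2O[C@H](CO)[C@@H](O)[C@H]2O)c(I)c1F`: > 50000 nM, a limit
Compound 2 `[N-]=[N+]=Nc1c(F)c(=O)[nH]c(=O)n1[C@@H]1O[C@H](CO)[C@@H](O)[C@H]1O`: 1500 nM

Going by the values given here, in a functional assay on OVCAR-4 cells (Homo sapiens) for antiproliferative activity, read by WST assay, with a stated time of 3 days (a lower number here means a stronger inhibitor, a higher number a weaker inhibitor), compound 2 gives 1500 nM, the only true number so far. Compound 1 stands at the limit of > 50000 nM in this assay, at which 1 of the 2 values shown sits. The next compound to be read is compound 3 `Nc1c(F)c(=O)[nH]c(=O)n1[C@@H]1O[C@H](CO)[C@@H](O)[C@H]1O`, which differs from compound 2 at one place: amino in place of azido on an aromatic carbon. In short, it carries amino in place of azido on an aromatic carbon.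

Among the compounds with values here, one measured step touches that same carbon: an at least 33-fold lower number from compound 1 to compound 2 (1.52 log units; beyond the scatter). It is large, but it exchanges iodo for azido, so it says nothing directly about amino. It shows only that this assay can respond strongly to the group at this place. Measurable activity has so far been seen only with the azido group of compound 2 at 1500 nM, so removing that group is expected to raise the number, probably beyond the scatter. The expected change is a 5.3-fold higher number from compound 2 to compound 3 (0.73 log units; beyond the scatter). For compound 3 the estimated value is 8000 nM, with an expected range of 1500 nM to 50000 nM.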

Compound 3, half-maximal inhibitory concentration: 2000 nM
Compound 3: the middle estimate sits 4.0-fold (0.60 log units) above what was measured; measured number inside the range.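

In this assay, the exchange of azido for amino gives a 1.3-fold higher number from compound 2 to compound 3 (0.12 log units; within the scatter), so at this aromatic carbon the two groups cannot be told apart, even though azido counts 3 heavy atoms and amino only 1. Measurable activity therefore does not depend on the azido group itself, and the large gain seen on leaving iodo is now shared by a second group, with an at least 25-fold lower number from compound 1 to compound 3 (1.39 log units; beyond the scatter). Compound 1, the only one of the three without a nitrogen-bearing group at this carbon, remains a limit and not a number: the limit of > 50000 nM in this assay, at which 1 of the 3 values shown sits.

The compounds shown leave open whether a nitrogen attached at this carbon is what matters, a question that a methylamino, a dimethylamino, a hydroxyl or a methoxy group at the same place would address, as would a chloro group as a smaller halogen than iodo. They also leave open whether azido and amino would still match if the fluoro group on the same ring were replaced by a hydrogen or a methyl group.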